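The source may hold more compounds than are shown below. What is called first, only, known or untested is meant among the compounds shown, and "the series" means these compounds.

Measured compounds:
Compound 1, `N#CC1=C(N)N(c2ccc(S(N)(=O)=O)cc2)C2=C(C(=O)CCC2)C1c1ccccc1`: in a functional assay on Ehrlich cells (Mus musculus) for antiproliferative activity, read by trypan blue exclusion, with a stated time of 2 h (on this read-out lower numbers stand for stronger inhibition and higher numbers for weaker inhibition), compound 1 gives > 100 ug/mL, a limit of the assay.
Compound 2, `N#CC1=C(N)N(c2ccc(S(N)(=O)=O)cc2)C2=C(C(=O)CCC2)C1/C=C/c1ccccc1`: compound 2 gives > 100 ug/mL, also a limit.
Compound 3, `COc1cc(CC2C(C#N)=C(N)N(c3ccc(S(N)(=O)=O)cc3)C3=C2C(=O)CCC3)ccc1O`: compound 3 gives 25 ug/mL.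

Compound 2 therefore stands at a limit rather than at a number, and it shares that position with one other compound, as the limit of > 100 ug/mL in this assay, at which 2 of the 3 values shown sit, shows. Compound 4, `N#CC1=C(N)N(c2ccc(S(N)(=O)=O)cc2)C2=C(C(=O)CCC2)C1c1cccc([N+](=O)[O-])c1`, is compound 2 with 3-nitrophenyl in place of 2-phenylethenyl on a saturated ring carbon.

The step that the two limits leave unreadable from compound 1 to compound 2 cannot be read, since both ends are limits. The step of an at least 4.0-fold lower number from compound 2 to compound 3 (0.60 log units; beyond the scatter) and the step of an at least 4.0-fold lower number from compound 1 to compound 3 (0.60 log units; beyond the scatter) both show a clearly lower number on moving to 4-hydroxy-3-methoxybenzyl. A 3-nitrophenyl group is closer in shape to the phenyl of compound 1 than to that benzyl group, and compound 1 gives > 100 ug/mL, a limit.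

Compound 4 is thus expected to remain near the limit, with an estimate of 100 ug/mL, ranging from 30 ug/mL to 300 ug/mL. This corresponds to an expected step of a number no higher from compound 2 to compound 4 (the limit leaves the size open), which may itself prove unreadable.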

Compound 4, half-maximal inhibitory concentration: 25 ug/mL
For compound 4 the middle estimate is 4.0-fold (0.60 log units) above the measured one, and the stated range ends above it.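

In this assay, nitro in place of hydrogen on the phenyl ring gives an at least 4.0-fold lower number from compound 1 to compound 4 (0.60 log units; beyond the scatter) and so shows that one small addition to the phenyl group is enough to reach a measurable value. The same carbon of the shared core also responds when 3-nitrophenyl replaces 2-phenylethenyl, with an at least 4.0-fold lower number from compound 2 to compound 4 (0.60 log units; beyond the scatter) as the result. Until now only the 4-hydroxy-3-methoxybenzyl group had given a measurable value here, but no change at the digits printed from compound 3 to compound 4 (within the scatter) shows that a group without that benzyl link or its hydroxy group can give the same printed number.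

From the compounds shown here alone, it remains open whether a chlorine, an amine or a carboxylic acid on the phenyl ring would also give a measurable value. The compounds shown also do not tell whether the nitro group would act in the same way at another carbon of that ring.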